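Removing the Protecting Group: From Compound 3 to Compound 4

This account rests on a few compounds, and the source may have more. Where it says the series, first, only, none or still open, it means among the compounds named here.

Measured so far:
- Compound 1, `CC[C@H](C)[C@H](NC(=O)c1cccc(Cn2ccnc2)c1)C(=O)NNS(=O)(=O)c1ccccc1`, 18%
- Compound 2, `CCCCS(=O)(=O)NNC(=O)[C@@H](NC(=O)c1cccc(Cn2ccnc2)c1)[C@@H](C)CC`, "not determined" (no result reported)
- Compound 3, `CC[C@H](C)[C@H](NC(=O)c1cccc(Cn2ccnc2)c1)C(=O)NNC(=O)OC(C)(C)C`, "not determined" (no result reported)

All three share one core and differ only in the group hanging off the terminal amide nitrogen. In an assay on HEK293 cells for displacement of a labelled ligand from Type-2 angiotensin II receptor (Homo sapiens), tested at 10 uM (a lower number here means a weaker effect, a higher number a stronger effect of the compound at the concentration tested), compound 1 gives 18%, a weak effect. For compound 3 no number exists, so it cannot be placed among the others. Compound 4, `CC[C@H](C)[C@H](NC(=O)c1cccc(Cn2ccnc2)c1)C(N)=O`, arises from compound 3 by the change (hydrogen in place of (tert-butoxycarbonyl)amino on an amide-type nitrogen). Since compound 3 carries no number, the size and direction of the step to compound 4 in this assay cannot be read from the data; the expectation rests on compound 1 alone. Compound 4 is expected to give about 10%, within 0% to 30%.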

Compound 4, a percentage reported as inhibition, at one concentration (the size of the read-out at that concentration, not a potency): "not active" (no number reported)
No number was reported for compound 4; no gap can be computed for the estimate.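

Among these compounds, neither compound 3 nor compound 4 has a number in this assay, so no step between them can be read, and no supporting data bear on this result. The compounds shown leave open what replacing (tert-butoxycarbonyl)amino with hydrogen does to the read-out.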